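A few compounds are considered here, and "the series" means these few. Any claim that something is new, unique, unknown or untested is made for them only; others in the source may bear on it.

Among the measured compounds shown here, compound 1, `O=C(NOCc1ccccc1)c1cn(-c2ccccc2)nc1-c1ccccc1`, is one of three compounds measured in a functional assay on HeLa cells (Homo sapiens) for antiproliferative activity, read by MTT assay, with a stated time of 48 h, in the presence of a further agent that is not named here (a higher number here means a weaker inhibitor of growth, a lower number a stronger inhibitor of growth), where compound 1 gives 8830 nM. Compound 2, `O=C(NOCc1ccccc1Cl)c1cn(-c2ccccc2)nc1-c1ccccc1`, gives 17800 nM, and compound 3, `O=C(NOCc1ccc(Cl)cc1Cl)c1cn(-c2ccccc2)nc1-c1ccccc1`, gives 5100 nM. Compound 1 thus holds the second highest of the three numbers: its nearest neighbour is compound 3, with a 1.7-fold lower number from compound 1 to compound 3 (0.24 log units; within the scatter), and its furthest is compound 2, with a 2.0-fold higher number from compound 1 to compound 2 (0.30 log units; within the scatter).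

Compound 4, `O=C(NOCc1ccccc1)c1cn(-c2ccccc2)nc1-c1ccc(Cl)cc1`, differs from compound 1 in a single place: chloro in place of hydrogen on an aromatic carbon. Here the chloro sits on a ring of carbon only that is attached to the shared core, para to a large group, whereas the chloro groups of compounds 2 and 3 sit on the ring that is bound through a saturated chain carbon to an oxygen. The two measured steps of this kind point in opposite directions: a 2.0-fold higher number from compound 1 to compound 2 (0.30 log units; within the scatter), and a 3.5-fold lower number from compound 2 to compound 3 (0.54 log units; beyond the scatter). Neither concerns the same ring as compound 4, so no clear direction can be drawn; a step within the scatter is expected, a 1.1-fold lower number from compound 1 to compound 4 (0.04 log units; within the scatter). Compound 4 is therefore estimated at 8000 nM, within 3500 nM to 18000 nM.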

Compound 4, concentration for 50% growth inhibition: 8350 nM
For compound 4 the middle estimate is 1.0-fold (0.02 log units) below the measured one; low and high end bracket the measured number.
By their numbers in this assay, from the lowest: compounds 3, 4, 1 and 2 (each within the scatter of the next, the first and the last beyond it).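

On the phenyl attached to the shared core, the change to 4-chlorophenyl gives a step within the scatter in this assay: a 1.1-fold lower number from compound 1 to compound 4 (0.02 log units; within the scatter). The earlier steps shown here involved only chloro groups on the other ring, the one bound through a saturated chain carbon to an oxygen, so they could not show how this position would respond. The result also shows that the size of this step does not carry over from one position to another: the same change on two cores in this assay, a 3.5-fold lower number (0.54 log units; beyond the scatter) from compound 2 to compound 3 and a 1.1-fold lower number (0.02 log units; within the scatter) from compound 1 to compound 4, 3.3-fold (0.52 log units) apart, beyond the scatter of two such steps

From the compounds shown here alone, whether another group at this position, such as an amine, a carboxylic acid or a methoxy group, would give a step beyond the scatter remains open. So does whether the chloro of compound 4 and the two chloro groups of compound 3 would add up within a single compound.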